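Swapping the Amide Headgroup in a Chemokine Receptor Series

The source may hold more compounds than are shown below. What is called first, only, known or untested is meant among the compounds shown, and "the series" means these compounds.

Measured compounds:
compound 1 `O=C(Cn1cnc2cccnc21)N1CCN(c2scnc2-c2nc3ccccc3[nH]2)CC1`: 1440 nM
compound 2 `Cc1ncc(-c2nc(C(F)(F)F)sc2N2CCN(C(=O)Cn3cnc4cccnc43)[C@H](C)C2)cn1`: 104 nM
compound 3 `CCOc1ncc(-c2nc(C(F)(F)F)sc2N2CCN(C(=O)Cn3ccc4cccnc43)[C@H](C)C2)cn1`: 47 nM

All three compounds were tested in an assay on blood for inhibition of C-X-C chemokine receptor type 3 (Homo sapiens), with a stated time of 30 min; a higher number here means a weaker inhibitor, a lower number a stronger inhibitor. Compound 3 has the lowest number of the three, so it is the strongest inhibitor in this assay: compound 2 stands a little higher, beyond the usual scatter, and compound 1 stands far higher still. Compound 4 `CCOc1ncc(-c2nc(C(F)(F)F)sc2N2CCN(C(=O)Cn3ccc(C(F)(F)F)n3)[C@H](C)C2)cn1` has not yet been measured. It keeps the whole of compound 3 except at the end of the amide: a group of 9 heavy atoms (4 carbon, 2 nitrogen, 3 fluorine; one five-membered aromatic ring with 2 hetero atoms) in place of a group of 9 heavy atoms (7 carbon, 2 nitrogen; one five-membered aromatic ring with 1 hetero atom, one six-membered aromatic ring with 1 hetero atom), on a saturated chain carbon bound to a carbonyl carbon. Among the measured compounds shown here, no pair of measured compounds differs only at this position, so there is no directly comparable step to lean on. The two measured compounds that share the rest of the core, compound 2 and compound 3, both carry a fused two-ring group at this spot, and compound 4 departs from that pattern. The expectation is a modest loss of potency, giving an estimated step of a 3.2-fold higher number from compound 3 to compound 4 (0.50 log units; beyond the scatter). Compound 4 is expected to give about 150 nM, within a range from 40 nM to 600 nM.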

Compound 4, half-maximal inhibitory concentration: 90 nM
The estimate for compound 4 lay 1.7-fold (0.22 log units) above the measured number; measured number inside the range.
By their numbers in this assay, from the lowest: compounds 3, 4 and 2 (each within the scatter of the next, the first and the last beyond it); then compound 1.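

The fused two-ring group at the end of the amide can give way to 3-(trifluoromethyl)-1H-pyrazol-1-yl, a single five-membered aromatic ring, with a 1.9-fold higher number from compound 3 to compound 4 (0.28 log units; within the scatter) in this assay. The two groups therefore cannot be told apart in this assay, so a fused second ring, carried by both earlier compounds on this core, is not required for a number of this size. Nothing available explains why the two groups read alike.

From the compounds shown here alone, whether the trifluoromethyl group itself matters remains open, and a pyrazole carrying a methyl or a chlorine in its place would help to settle that. Also open, going by these compounds, is whether a longer chain in place of the saturated chain carbon would give a similar number.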